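This account rests on a few compounds, and the source may have more. Where it says the series, first, only, none or still open, it means among the compounds named here.

Compound 1 `COc1ccc(-c2cc(-c3cccc(S(C)(=O)=O)c3)cnc2N)cn1` is the starting point. In a physicochemical assay for solubility, read by nephelometry, measured as kinetic solubility, at pH 2 (a lower number here means a less soluble compound, a higher number a more soluble compound), compound 1 gives > 100 ug/mL, which is a limit of the assay rather than a number. Compound 2 `COc1ccc(-c2cc(-c3ccc(C(F)(F)F)cc3)cnc2N)cn1` gives > 100 ug/mL in this assay, also a limit. Compound 3 `COc1ccc(-c2cc(-c3ccc(-n4cncn4)cc3)cnc2N)cn1` gives > 100 ug/mL in this assay, again a limit. Within the data shown here, every value so far is the limit of > 100 ug/mL in this assay, at which 3 of the 3 values shown sit. Among the measured compounds shown here, the only measured step is a step that the two limits leave unreadable from compound 2 to compound 3. Compound 4 `COc1ccc(-c2cc(-c3cccc(C(N)=O)c3)cnc2N)cn1` differs from compound 1 by carbamoyl in place of methylsulfonyl on an aromatic carbon. For the measured compounds named here, no measured step bears on this change, so the expectation rests on compound 1 standing at the limit of > 100 ug/mL in this assay, at which 3 of the 3 values shown sit, and the step of a number no higher from compound 1 to compound 4 (the limit leaves the size open) is expected to be none beyond the scatter. Compound 4 is therefore estimated at 100 ug/mL, with a range from 50 ug/mL to 200 ug/mL.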

Compound 4, solubility: > 100 ug/mL
Compound 4: only a limit was reported (the forecaster's own chance of this, stated with the estimate: 80%); the middle value sits exactly at the limit.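

No step can be read from compound 1 to compound 4, because neither result is a number: the limit of > 100 ug/mL in this assay, at which 4 of the 4 values shown sit.

The compounds shown leave open how soluble each one actually is, and whether carbamoyl in place of methylsulfonyl changes this assay at all.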